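The compounds below may be only part of what the source reports. "The series", "measured", "known", "first", "only" and "open" are said of these compounds alone.

Among the measured compounds shown here, in a functional assay on HCC827 cells (Homo sapiens) for antiproliferative activity, read by MTT assay, with a stated time of 72 h (on this read-out lower numbers stand for stronger inhibition and higher numbers for weaker inhibition), compound 1 `CN1CCN(c2ccc(Nc3ncc4nc([S+]([O-])c5ccccc5)n(CC5CC5)c4n3)cc2)CC1` gives 838 nM and compound 2 `CN1CCN(c2ccc(Nc3ncc4nc([S+]([O-])c5ccccc5)n(C5CCOCC5)c4n3)cc2)CC1` gives 411 nM, the lower of the two numbers so far. Compound 3 `CN1CCN(c2ccc(Nc3ncc4nc([S+]([O-])c5ccccc5)n(C5CC5)c4n3)cc2)CC1` shares their core and differs from compound 2 as follows: cyclopropyl in place of oxan-4-yl on an aromatic nitrogen. In words, this is cyclopropyl in place of oxan-4-yl on an aromatic nitrogen. For the measured compounds named here, only one measured step bears on this place, and it is modest: a 2.0-fold lower number from compound 1 to compound 2 (0.31 log units; beyond the scatter), with oxan-4-yl in place of cyclopropylmethyl on an aromatic nitrogen. Compound 3 gives up the oxan-4-yl and, like compound 1, carries a three-membered ring of carbon only. A modest step toward a higher number is therefore expected in this assay, possibly not clear of the scatter, though a single step is thin support. The estimated step is a 1.7-fold higher number from compound 2 to compound 3 (0.23 log units; within the scatter). For compound 3 the expected value is 700 nM, with an estimated range of 280 nM to 1700 nM.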

Compound 3, half-maximal inhibitory concentration: 1630 nM
Estimate against measurement, compound 3: 2.3-fold (0.37 log units) below, and the stated range covers the measured number.
By their numbers in this assay, from the lowest: compound 2; then compounds 1 and 3 (each within the scatter of the next).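

In this assay, cyclopropyl in place of oxan-4-yl on the aromatic nitrogen gives a 4.0-fold higher number from compound 2 to compound 3 (0.60 log units; beyond the scatter), so the lower number of compound 2 now stands clear of both carbon-only groups rather than of cyclopropylmethyl alone. Cyclopropyl in place of cyclopropylmethyl gives a 1.9-fold higher number from compound 1 to compound 3 (0.29 log units; within the scatter), so these two groups are not told apart in this assay, and among the three compounds only the oxan-4-yl group separates from the others at this position. Nothing given here explains this difference.

The oxan-4-yl group differs from both other groups in its ring size as well as in its ring oxygen, so the compounds shown do not say which of the two goes with the lower number. A cyclohexyl or a piperidin-4-yl group on this nitrogen would bear on that question.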